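A Halogen Swap on the Aryl Amide of Compound 1

The compounds below may be only part of what the source reports. "The series", "measured", "known", "first", "only" and "open" are said of these compounds alone.

Compound 1 `CC(C)OC(=O)C1CN(C(=O)c2ccc(F)cc2)CC(C)(C)c2cc(C#N)[nH]c21` is an aryl amide on a bicyclic core; in an assay on HEK293 cells for agonist activity at Bile acid receptor (Homo sapiens), read by a luciferase reporter (on this read-out higher numbers stand for larger maximal responses and lower numbers for smaller maximal responses), compound 1 reaches 85%. Compound 2 `CC(C)OC(=O)C1=CN(C(=O)c2cccc(C(F)(F)F)c2)CC(C)(C)c2cc(C#N)[nH]c21` gives 94% in this assay, so compound 1 stands lowest of the two measured numbers, yet the gap to compound 2 lies within the usual scatter. Compound 3 `CC(C)OC(=O)C1CN(C(=O)c2cccc(Cl)c2)CC(C)(C)c2cc(C#N)[nH]c21` carries 3-chlorophenyl in place of 4-fluorophenyl on a carbonyl carbon. For the measured compounds named here, no measured pair differs in only this way, so the size of this step is unknown. The expected step of a number 3 percentage points higher from compound 1 to compound 3 (within the scatter) lies within the scatter. Compound 3 is therefore estimated at 88%, in the range 70% to 105%.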

Compound 3, largest response reached (reported as efficacy), in percent of the reference or control that the assay uses: 103%
Estimate against measurement, compound 3: 15 percentage points below, within the range that was stated.
By their numbers in this assay, from the lowest: compounds 1, 2 and 3 (each within the scatter of the next, the first and the last beyond it).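

Placing 3-chlorophenyl in place of 4-fluorophenyl on the carbonyl carbon gives a first readable step at this position, a number 18 percentage points higher from compound 1 to compound 3 (beyond the scatter), which shows that the largest response depends on the aryl group here. Compound 1 and compound 2 differ in more than one place and could not show this. The halogen and its ring position change together in this single pair, and nothing available accounts for the step.

Which of the two changes carries the step stays open, and 3-fluorophenyl or 4-chlorophenyl on the same carbonyl carbon would separate them. Going by these compounds, how an aminophenyl group would read at this position also stays open.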